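Swapping Chloro for Bromo at the Limit

A few compounds are considered here, and "the series" means these few. Any claim that something is new, unique, unknown or untested is made for them only; others in the source may bear on it.

Measured in a functional assay on DU-145 cells (Homo sapiens) for antiproliferative activity, read by MTT assay, with a stated time of 72 h; a higher number here means a weaker inhibitor, a lower number a stronger inhibitor:
- Compound 1 `CN(c1ccc(Cl)cc1)S(=O)(=O)C1CC2OC1C(c1ccc(NC(=O)CCCCCCC(=O)O)cc1)=C2c1ccc(O)cc1`: 72100 nM
- Compound 2 `CCN(c1ccccc1Cl)S(=O)(=O)C1CC2OC1C(c1ccc(NC(=O)CCCCCCC(=O)O)cc1)=C2c1ccc(O)cc1`: > 100000 nM

The value for compound 2 is a limit, not a number. Compound 2 therefore stands at the limit of > 100000 nM in this assay, at which 1 of the 2 values shown sits.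

Compound 3 `CCN(c1ccccc1Br)S(=O)(=O)C1CC2OC1C(c1ccc(NC(=O)CCCCCCC(=O)O)cc1)=C2c1ccc(O)cc1` differs from compound 2 by one swap: bromo in place of chloro on an aromatic carbon. It has bromo in place of chloro on an aromatic carbon, ortho to a large group.

For the measured compounds named here, only one measured step offers any guidance: an at least 1.3-fold higher number from compound 1 to compound 2 (0.14 log units; that floor lies within the scatter). That step replaces (4-chlorophenyl)(methyl)amino with (2-chlorophenyl)(ethyl)amino, so it does not test a bromo for chloro swap. No step beyond the scatter is therefore expected in this assay, and a further limit is quite likely.

The estimate for this swap is an expected a number no higher from compound 2 to compound 3 (the limit leaves the size open).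

Compound 3 is estimated at 100000 nM, within an expected range of 45000 nM to 220000 nM.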

Compound 3, half-maximal inhibitory concentration: 95300 nM
Beside the measured number, compound 3's estimate is 1.0-fold (0.02 log units) above it, and the stated range covers the measured number.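

Compound 2 carries a limit rather than a number: the limit of > 100000 nM in this assay, at which 1 of the 3 values shown sits. On these data alone, with bromo in place of chloro on an aromatic carbon, ortho to a large group, the swap now has a measured number on one side in this assay, and it reads as an at least 1.0-fold lower number from compound 2 to compound 3 (0.02 log units; that floor lies within the scatter), so only a floor is known and the true size of the swap stays open. Putting (2-bromophenyl)(ethyl)amino in place of (4-chlorophenyl)(methyl)amino gives a 1.3-fold higher number from compound 1 to compound 3 (0.12 log units; within the scatter), so these two groups cannot be told apart here.

Whether any other group on this aromatic carbon would move the number beyond the scatter remains open, since the compounds shown carry only chloro and bromo there, with no fluoro, methoxy or amine. Also open, as far as these compounds go, is what a hydroxamic acid would do in place of the carboxylic acid at the end of the chain.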